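The compounds below may be only part of what the source reports. "The series", "measured", "known", "first", "only" and "open" are said of these compounds alone.

Measured compounds:
compound 1, `CC1=CCC2C(CC[C@@]2(C)O)C(C)(C)C1CC[C@@H]1[C@@]2(C)CC[C@@H](O)C(C)(C)O[C@@H]2CC[C@]1(C)O`: 44500 nM
compound 2, `CC1=CC[C@H]2[C@H](CC[C@]2(C)O)C(C)(C)[C@@H]1CC[C@H]1[C@]2(C)CC[C@H](OC(=O)c3ccc([N+](=O)[O-])cc3)C(C)(C)O[C@H]2CC[C@@]1(C)O`: 21600 nM

Both were tested in a functional assay on MCF7 cells (Homo sapiens) for antiproliferative activity, read by MTT assay, with a stated time of 72 h; a higher number here means a weaker inhibitor, a lower number a stronger inhibitor. Of the two, compound 2 gives the lower number, and the gap to compound 1 lies beyond the usual scatter, so compound 2 is the more potent of the pair. Among the measured compounds shown here, no single-change step between them is available, so only their two values can be compared.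

Compound 3, `CC1=CC[C@H]2[C@H](CC[C@]2(C)O)C(C)(C)[C@@H]1CC[C@H]1[C@]2(C)CC[C@H](OC(=O)c3ccc(C(F)(F)F)c(F)c3)C(C)(C)O[C@H]2CC[C@@]1(C)O`, has not yet been measured. It differs from compound 2 in one place: 3-fluoro-4-(trifluoromethyl)phenyl in place of 4-nitrophenyl on a carbonyl carbon. For the measured compounds named here, nothing among the measured compounds tells how this assay responds to an exchange of one aryl ester for another, so no step beyond the scatter is expected in either direction. Compound 3 is therefore estimated at 22000 nM, with a likely range from 8000 nM to 60000 nM. The step that this estimate implies, a 1.0-fold higher number from compound 2 to compound 3 (0.01 log units; within the scatter), is expected to stay within the scatter.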

Compound 3, half-maximal inhibitory concentration: > 50000 nM
Compound 3: no number, only a limit (the forecaster's own chance of this, stated with the estimate: 10%); middle value at least 2.2-fold (0.35 log units) away from the limit.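

In this assay, the aryl group on this carbonyl carbon turns out to matter: 3-fluoro-4-(trifluoromethyl)phenyl in place of 4-nitrophenyl gives an at least 2.3-fold higher number from compound 2 to compound 3 (0.36 log units; beyond the scatter). Compound 3 gives > 50000 nM, which is a limit of the assay and not a number. The full size of this loss of potency cannot be read, because the step rests on that limit: the limit of > 50000 nM in this assay, at which 1 of the 3 values shown sits.

The compounds shown leave open whether the loss goes with the arrival of the fluorine, with the arrival of the trifluoromethyl group or with the departure of the nitro group. They also leave open how a plain phenyl, a 4-aminophenyl or a simple acetyl ester would stand at this place on the shared core.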